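This account rests on a few compounds, and the source may have more. Where it says the series, first, only, none or still open, it means among the compounds named here.

Series with the shared core of compound 1 `O=C1NC(=O)/C(=C/c2ccc(OCCSc3nnc(Cc4ccccc4)[nH]3)cc2)S1` carried through compound 2 `Cc1ccc(-c2nnc(SCCOc3ccc(/C=C4\SC(=O)NC4=O)cc3)[nH]2)cc1` and compound 3 `O=C1NC(=O)/C(=C/c2ccc(OCCSc3nnc(-c4ccc(Cl)cc4)[nH]3)cc2)S1`. In a functional assay on the whole organism (strain Wistar) with Rattus norvegicus as the target, with a stated time of 15 days, at a dose of 3 mg/kg by the oral route (a higher number here means a stronger effect of the compound at the dose given, a lower number a weaker effect), compound 1 gives 22.5%. In this assay compound 2 gives 25.2%, and compound 3 gives 23.9%. Compound 3 stands second of the three numbers, but its nearest neighbour is compound 2 and the step of a number 1.3 percentage points lower from compound 2 to compound 3 (within the scatter) lies within the scatter, as does a number 1.4 percentage points higher from compound 1 to compound 3 (within the scatter); the three numbers therefore cannot be ordered.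

Compound 4 `COc1ccc(-c2nnc(SCCOc3ccc(/C=C4\SC(=O)NC4=O)cc3)[nH]2)cc1` is not yet measured. It differs from compound 3 as follows: methoxy in place of chloro on an aromatic carbon. Going by the values given here, no measured step exchanges chloro for methoxy. Among the compounds with values here, the only step that touches the same position is a number 1.3 percentage points lower from compound 2 to compound 3 (within the scatter), which swaps chloro for methyl and stays within the scatter; the steps of a number 2.7 percentage points higher from compound 1 to compound 2 (within the scatter) and a number 1.4 percentage points higher from compound 1 to compound 3 (within the scatter), which change the whole aryl group, are also within the scatter. For this assay no step beyond the scatter is therefore expected from compound 3 to compound 4, the estimated step being a number 0.1 percentage points higher from compound 3 to compound 4 (within the scatter). Compound 4 is estimated at 24%, with a range from 14% to 34%.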

Compound 4, a percentage reported as activity, at one dose (the size of the read-out at that dose, not a potency): 43.1%
Estimate against measurement, compound 4: 19.1 percentage points below; measured number above the stated range.
By their numbers in this assay, from the lowest: compounds 1, 3 and 2 (each within the scatter of the next); then compound 4.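

On an aromatic carbon para to a large group, this position proves responsive in this assay: methoxy in place of chloro gives a number 19.2 percentage points higher from compound 3 to compound 4 (beyond the scatter) and methoxy in place of methyl gives a number 17.9 percentage points higher from compound 2 to compound 4 (beyond the scatter) while chloro and methyl themselves could not be told apart. Replacing benzyl with 4-methoxyphenyl likewise gives a number 20.6 percentage points higher from compound 1 to compound 4 (beyond the scatter) and so, unlike the 4-methylphenyl and 4-chlorophenyl changes, this exchange of the whole group exceeds the scatter. No measurement on hand explains the effect of methoxy.

The compounds shown leave open whether the oxygen alone carries the gain, which a hydroxy group in the same place would test. From the compounds shown here alone, it also remains open whether a longer chain such as ethoxy or an amine such as dimethylamino would keep it.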